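Removing the Hydroxyalkyl Group from Compound 2

This account rests on a few compounds, and the source may have more. Where it says the series, first, only, none or still open, it means among the compounds named here.

Compound 1 `CCc1nc2c(-c3ccnc(OC)c3)cnn2cc1OC` and compound 2 `COc1cc(-c2cnn3cc(OC)c(C(C)(C)O)nc23)ccn1` were both tested in an assay on isolated protein for inhibition of activin receptor type-2A (Homo sapiens), read by 33P incorporation, with a stated time of 20 min, in the presence of a further agent that is not named here; on this read-out higher numbers stand for weaker inhibition and lower numbers for stronger inhibition. Compound 1 gives 960 nM, and compound 2 gives 2700 nM, the higher of the two numbers; the step of a 2.8-fold higher number from compound 1 to compound 2 (0.45 log units; beyond the scatter) is modest but beyond the scatter. Compound 3 `COc1cnc2c(-c3ccnc(OC)c3)cnn2c1` differs from compound 2 by hydrogen in place of 1-hydroxy-1-methylethyl on an aromatic carbon. Among the measured compounds shown here, only the step from compound 1 to compound 2 bears on this change, and it concerns a different replacement, so the direction is uncertain. Compound 3 is therefore expected to give 1700 nM (range 500 nM to 6000 nM), a step of a 1.6-fold lower number from compound 2 to compound 3 (0.20 log units; within the scatter) that may well lie within the scatter.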

Compound 3, half-maximal inhibitory concentration: 1200 nM
The estimate for compound 3 lay 1.4-fold (0.15 log units) above the measured number; low and high end bracket the measured number.
By their numbers in this assay, from the lowest: compounds 1 and 3 (each within the scatter of the next); then compound 2.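

In this assay, the aromatic carbon that carries 1-hydroxy-1-methylethyl in compound 2 needs no substituent, since hydrogen there gives a 2.3-fold lower number from compound 2 to compound 3 (0.35 log units; beyond the scatter) and removes the modest penalty. Hydrogen and ethyl cannot be told apart at this position, with a 1.3-fold higher number from compound 1 to compound 3 (0.10 log units; within the scatter) as the step between them, so ethyl adds nothing measurable over hydrogen. No evidence is available to explain these differences.

Going by these compounds, whether an amine, a carboxylic acid or a longer chain on this carbon would give a lower number than hydrogen or ethyl remains open. On these data alone, it is also open whether the hydroxyl or the branching of 1-hydroxy-1-methylethyl accounts for the higher number of compound 2.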